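The source may hold more compounds than are shown below. What is called first, only, known or untested is meant among the compounds shown, and "the series" means these compounds.

Measured so far in an in vitro ADME assay on microsomes from liver (Homo sapiens) for metabolic stability; a lower number here means slower removal, a higher number faster removal of the compound:
Compound 1 `COc1ccc(-c2cc(-c3ccc(NS(C)(=O)=O)cc3)cnc2N)cn1` is reported only as an assay limit, < 7 mL.min-1.g-1.
Compound 2 `COc1ccc(-c2cc(-c3ccc(C(F)(F)F)cc3)cnc2N)cn1` gives 6.1 mL.min-1.g-1.
Compound 3 `COc1ccc(-c2cc(-c3ccc(-n4cncn4)cc3)cnc2N)cn1` gives 8 mL.min-1.g-1.

Of the two plain numbers, compound 3 has the higher one, with compound 2 nearest at a 1.3-fold higher number from compound 2 to compound 3 (0.12 log units; within the scatter); compound 1 adds only a limit. Compound 4 `COc1ccc(-c2cc(-c3ccc(C(N)=O)cc3)cnc2N)cn1` differs from compound 3 by carbamoyl in place of 1H-1,2,4-triazol-1-yl on an aromatic carbon. For the measured compounds named here, no measured step introduces a carbamoyl, so the closest guidance comes from the swaps at this same place, a 1.3-fold higher number from compound 2 to compound 3 (0.12 log units; within the scatter) and an at least 1.1-fold higher number from compound 1 to compound 3 (0.05 log units; that floor lies within the scatter), neither readable as more than the scatter. Exchanging the triazolyl once more is therefore expected to move this assay by nothing beyond the scatter. Compound 4 is estimated at 7 mL.min-1.g-1, in the range 4 mL.min-1.g-1 to 12 mL.min-1.g-1. That amounts to an expected step of a 1.1-fold lower number from compound 3 to compound 4 (0.06 log units; within the scatter).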

Compound 4, intrinsic clearance in microsomes: < 7 mL.min-1.g-1
Compound 4 ended at the assay's limit; the forecaster's own chance of this, stated with the estimate: 35%; the middle value sits exactly at the limit.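

Replacing the triazolyl with carbamoyl at this place on the aromatic ring gives an at least 1.1-fold lower number from compound 3 to compound 4 (0.05 log units; that floor lies within the scatter), so a ring-free group with fewer heavy atoms produces no readable change in this assay. The steps from compound 1 and compound 2 to compound 4 cannot be read. Compound 4 now joins compound 1 in being reported only as a limit, which hides the true numbers for both: the limit of < 7 mL.min-1.g-1 in this assay, at which 2 of the 4 values shown sit.

On these data alone, it remains open where compound 1 and compound 4 truly lie. As far as these compounds go, it is also open whether a carboxylic acid or a simple amine at this place would move the number beyond the scatter.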